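The source may report more compounds than this note shows. Statements on the series, on what has been measured and on what is new or still open speak of the compounds shown alone.

Two compounds sharing one core have numbers in a functional assay on SH-SY5Y cells (Homo sapiens) for inhibition, read by sulforhodamine B assay; a lower number here means a stronger inhibitor, a higher number a weaker inhibitor. Compound 1 `COC(=O)CC/C(C)=C/Cc1c(OC)c(C)c2c(c1OCC#CCN1CCN(c3ccccc3F)CC1)C(=O)OC2` gives 35800 nM, and compound 2 `COC(=O)CC/C(C)=C/Cc1c(OC)c(C)c2c(c1OCC#CCN1CCN(c3ccccc3OC)CC1)C(=O)OC2` gives 43600 nM. Among the compounds with values here, compound 2 therefore stands level with compound 1, the only other compound measured, as the two values lie within the scatter of each other.

Compound 3 `COC(=O)CC/C(C)=C/Cc1c(OC)c(C)c2c(c1OCC#CCN1CCN(c3ccc(C)cc3)CC1)C(=O)OC2` carries 4-methylphenyl in place of 2-methoxyphenyl on an amine nitrogen in a ring. Within the data shown here, one measured step bears on this change. Methoxy in place of fluoro on an aromatic carbon gave a 1.2-fold higher number from compound 1 to compound 2 (0.09 log units; within the scatter), a small step that stays within the scatter. Among the measured compounds shown here, that swap involved a different pair of groups, and no methyl-bearing compound has been measured, so it is only a loose guide. On this single step, no change beyond the scatter is expected in this assay. The estimated step is a 1.1-fold lower number from compound 2 to compound 3 (0.04 log units; within the scatter), and the range is kept wide to reflect how little evidence there is. For compound 3 the expected value is 40000 nM, with an estimated range of 18000 nM to 80000 nM.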

Compound 3, half-maximal inhibitory concentration: 37700 nM
Compound 3: middle estimate off by 1.1-fold (0.03 log units), on the high side; low and high end bracket the measured number.
By their numbers in this assay, from the lowest: compounds 1, 3 and 2 (each within the scatter of the next).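

Within this assay, putting 4-methylphenyl in place of 2-methoxyphenyl on the amine nitrogen in the ring gives a 1.2-fold lower number from compound 2 to compound 3 (0.06 log units; within the scatter) and putting it in place of 2-fluorophenyl gives a 1.1-fold higher number from compound 1 to compound 3 (0.02 log units; within the scatter) with the rest of the molecule unchanged. The earlier pair offered only 2-fluorophenyl and 2-methoxyphenyl, whereas this result adds a group with its substituent at the 4 position of the phenyl ring, and all three compounds stand level in this assay. The swap from compound 2 to compound 3 also takes the group from 1 hydrogen-bond acceptor to 0 without moving the number beyond the scatter, and no supporting measurement is available to explain why these groups read alike.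

On these data alone, it remains open whether a very different group on this nitrogen, such as a pyridine ring, a cyclohexyl ring or a benzyl group, or a phenyl ring bearing a carboxylic acid or an amine, would shift the number beyond the scatter. As far as these compounds go, the methyl ester and the alkyne-containing chain are the same in all three compounds, so the effect of a carboxylic acid at that ester or of a longer chain also remains unknown.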